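Replacing the Methoxyphenyl Ketone with an Aminothiophene Ketone

This account rests on a few compounds, and the source may have more. Where it says the series, first, only, none or still open, it means among the compounds named here.

Compound 1 `COc1ccc(C(=O)/C=C/c2nc3ccccc3cc2-c2ccc(OC)cc2)cc1` gives 8500 nM in a functional assay on A549 cells (Homo sapiens) for antiproliferative activity, read by XTT assay, with a stated time of 72 h; a lower number here means a stronger inhibitor, a higher number a weaker inhibitor. Among the three measured compounds it has the highest number, but both of its steps to the others stay within the scatter, so no real order can be read from this. Compound 2 `COc1ccc(-c2cc3ccccc3nc2/C=C/C(=O)c2ccco2)cc1` gives 6130 nM in this assay, and compound 3 `COc1ccc(-c2cc3ccccc3nc2/C=C/C(=O)c2ccc(Br)s2)cc1` gives 6250 nM. The steps are small: a 1.4-fold lower number from compound 1 to compound 2 (0.14 log units; within the scatter), a 1.4-fold lower number from compound 1 to compound 3 (0.13 log units; within the scatter) and a 1.0-fold higher number from compound 2 to compound 3 (0.01 log units; within the scatter).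

Compound 4 `COc1ccc(-c2cc3ccccc3nc2/C=C/C(=O)c2sccc2N)cc1` has not yet been measured. It differs from compound 1 in one place: 3-aminothiophen-2-yl in place of 4-methoxyphenyl on a carbonyl carbon. The two measured steps that bear on this are those from compound 1 to compound 2 and from compound 1 to compound 3, each exchanging the 4-methoxyphenyl on the carbonyl carbon for a five-membered aromatic ring; neither moved the number beyond the scatter. Since 3-aminothiophen-2-yl is again a five-membered aromatic ring at the same place, a similarly small step is expected, leaning slightly toward a lower number in line with a 1.4-fold lower number from compound 1 to compound 3 (0.13 log units; within the scatter). For compound 4 the expected step is a 1.5-fold lower number from compound 1 to compound 4 (0.19 log units; within the scatter), giving an estimate of 5500 nM with a range from 2000 nM to 15000 nM.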

Compound 4, half-maximal inhibitory concentration: > 10000 nM
Compound 4 gave a limit, no number (the forecaster's own chance of this, stated with the estimate: 5%); middle value at least 1.8-fold (0.25 log units) from the limit.
By their numbers in this assay, from the lowest: compounds 2, 3 and 1 (each within the scatter of the next). At a limit, above all of these: compound 4.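

Among these compounds, compound 4 is the only one of the four compounds that ends at a limit and not at a number: the limit of > 10000 nM in this assay, at which 1 of the 4 values shown sits. Set against the others, it gives only floors: an at least 1.1-fold higher number from compound 1 to compound 4 (0.07 log units; that floor lies within the scatter), an at least 1.6-fold higher number from compound 3 to compound 4 (0.20 log units; that floor lies within the scatter) and an at least 1.6-fold higher number from compound 2 to compound 4 (0.21 log units; that floor lies within the scatter). The earlier exchanges on the carbonyl carbon all gave readable numbers within the scatter of one another, whereas 3-aminothiophen-2-yl shows that a five-membered aromatic ring here does not always give a readable number in this assay, although none of these floors shows a change beyond the scatter.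

The true value of compound 4 stays open, so how far it lies from compounds 1, 2 and 3 cannot be told, and nothing shown separates the part played by the amine from that of the thiophene ring that carries it. An unsubstituted thiophen-2-yl, or the same ring with an acetamide or a methyl group in place of the amine, would be needed to tell these apart.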